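This account rests on a few compounds, and the source may have more. Where it says the series, first, only, none or still open, it means among the compounds named here.

Measured in an ADME assay on microsomes from liver (Rattus norvegicus) for metabolic stability, read by LC-MS, using NADPH, at 37 degrees C; a higher number here means that the compound lasts longer, a lower number that the compound disappears faster:
- Compound 1 `Cc1ccc(C)c(-c2nc(CN3CCC(C(=O)NCCCN4C[C@H](C)C[C@H](C)C4)CC3)c(C)o2)c1`: 0.5 h
- Compound 2 `Cc1cccc(-c2nc(CN3CCC(C(=O)NCCCN4C[C@H](C)C[C@H](C)C4)CC3)c(C)o2)c1`: > 0.5 h

Compound 2 stands at a limit of this assay, not at a number: the limit of > 0.5 h in this assay, at which 1 of the 2 values shown sits. Compound 3 `COc1cccc(F)c1-c1nc(CN2CCC(C(=O)NCCCN3C[C@H](C)C[C@H](C)C3)CC2)c(C)o1` is not yet measured and differs from compound 2 as follows: 2-fluoro-6-methoxyphenyl in place of 3-methylphenyl on an aromatic carbon. Going by the values given here, one measured step bears on this change, since it falls on the same phenyl group: a number no lower from compound 1 to compound 2 (the limit leaves the size open). As far as these compounds go, its size stays open, so it supplies no size or direction to carry over, and no step beyond the scatter is expected in this assay. The expected step is a number no higher from compound 2 to compound 3 (the limit leaves the size open). For compound 3 the estimate is 0.5 h, with an expected range of 0.25 h to 1 h.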

Compound 3, half-life: 0.143 h
Estimate against measurement, compound 3: 3.5-fold (0.54 log units) above, outside the stated range (below it).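

In this assay, the phenyl group on the shared core gives its first readable change with 2-fluoro-6-methoxyphenyl: an at least 3.4-fold lower number from compound 2 to compound 3 (0.54 log units; beyond the scatter), and a 3.5-fold lower number from compound 1 to compound 3 (0.54 log units; beyond the scatter). The earlier step between compound 1 and compound 2 cannot be read, whereas both new steps lie beyond the scatter, so the half-life does respond to the group at this position. The first of these steps remains a bound, since compound 2 stands at a limit: the limit of > 0.5 h in this assay, at which 1 of the 3 values shown sits.

As far as these compounds go, the fluoro and methoxy parts enter together, so which of them goes with the shorter half-life remains open. Also open, from the compounds shown here alone, is how a phenyl carrying a nitrile or an amine would read here.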